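The source may hold more compounds than are shown below. What is called first, only, known or untested is meant among the compounds shown, and "the series" means these compounds.

Measured so far in an assay on isolated protein (kidney, strain Wistar) for displacement of a labelled ligand from Translocator protein (Rattus norvegicus), read by scintillation counting, with a stated time of 90 min; a higher number here means a weaker inhibitor, a lower number a stronger inhibitor:
compound 1 `CCN(CC)C(=O)Cc1c(-c2ccc(OC3CCC3)cc2)nn2c(C)cc(C)nc12`, 0.86 nM
compound 2 `CCN(CC)C(=O)Cc1c(-c2ccc(OCc3ccccc3)cc2)nn2c(C)cc(C)nc12`, 0.99 nM
compound 3 `CCN(CC)C(=O)Cc1c(-c2ccc(OCc3ccc(F)cc3)cc2)nn2c(C)cc(C)nc12`, 0.77 nM

Compound 3 gives the lowest number of the three, but its distances to compound 1 and to compound 2 both fall within the scatter, so no order among the three can be read. Compound 4 `CCN(CC)C(=O)Cc1c(-c2ccc(OCCc3ccccc3)cc2)nn2c(C)cc(C)nc12` is not yet measured. Relative to compound 3 the change is benzyl in place of 4-fluorophenyl on a saturated chain carbon bound to an oxygen on an aromatic ring. Within the data shown here, no measured step makes this exact change. The nearest guides are a 1.1-fold lower number from compound 1 to compound 3 (0.05 log units; within the scatter) and a 1.2-fold higher number from compound 1 to compound 2 (0.06 log units; within the scatter), where exchanging the whole group on the oxygen left the number within the scatter, and a 1.3-fold lower number from compound 2 to compound 3 (0.11 log units; within the scatter), also within the scatter. On that basis no step beyond the scatter is expected in this assay. For compound 4 the estimate is 1 nM, with a range of 0.4 nM to 2.5 nM, an expected step of a 1.3-fold higher number from compound 3 to compound 4 (0.11 log units; within the scatter).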

Compound 4, inhibition constant: 0.13 nM
Beside the measured number, compound 4's estimate is 7.7-fold (0.89 log units) above it; the whole stated range lies above it.
By their numbers in this assay, from the lowest: compound 4; then compounds 3, 1 and 2 (each within the scatter of the next).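

In this assay, among these compounds, phenethyl on the oxygen on the aromatic ring gives the first steps beyond the scatter: a 5.9-fold lower number from compound 3 to compound 4 (0.77 log units; beyond the scatter), a 7.6-fold lower number from compound 2 to compound 4 (0.88 log units; beyond the scatter) and a 6.6-fold lower number from compound 1 to compound 4 (0.82 log units; beyond the scatter). Cyclobutyl, benzyl and 4-fluorobenzyl on that oxygen had left the numbers within the scatter of one another, so the earlier compounds gave no sign that this position could move the number. No measured evidence accounts for the step. Still open, going by these compounds, is whether a longer chain, such as phenylpropyl, continues the change. Also open, on these data alone, is how 4-fluorophenethyl or an amine in place of the phenyl would read.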